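The source may hold more compounds than are shown below. What is called first, only, known or untested is meant among the compounds shown, and "the series" means these compounds.

Of the compounds shown here, two carry a number so far. Compound 1 `Nc1ccccc1NC(=O)c1ccc(CSC(=S)N2CCN(Cc3ccccn3)CC2)cc1` in a functional assay on A-375 cells (Homo sapiens) for antiproliferative activity, read by CCK-8 assay, with a stated time of 72 h, tested at 8 uM (on this read-out lower numbers stand for a weaker effect and higher numbers for a stronger effect at the one concentration tested), gives 82.4%. Compound 2 `Nc1ccccc1NC(=O)c1ccc(CSC(=S)N(Cc2ccccc2)Cc2ccccc2)cc1` in this assay gives 32.5%. Compound 1 stands highest of the two numbers; compound 2 is its nearest neighbour and sits beyond the scatter below it. Going by the values given here, no single-change step between measured compounds is available, so the gap between compound 1 and compound 2 shows only that the two numbers differ, not the weight of any one alteration.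

Compound 3 `Nc1ccccc1NC(=O)c1ccc(CSC(=S)N2CCN(c3ccncc3)CC2)cc1` is the next compound to be measured in this assay. Relative to compound 1 it differs in one place: pyridin-4-yl in place of (pyridin-2-yl)methyl on an amine nitrogen in a ring. Compound 1 remains the only reference bearing the six-membered non-aromatic ring with 2 nitrogen; compound 2 lacks it and says nothing about this change. Among the compounds with values here, with no measured step for guidance, the change from compound 1 to compound 3 is expected to give a modest downward step, a number 17.4 percentage points lower from compound 1 to compound 3 (beyond the scatter), which may or may not exceed the scatter. Compound 3 is estimated at 65%, with a range from 35% to 90%.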

Compound 3, a percentage reported as inhibition, at one concentration (the size of the read-out at that concentration, not a potency): 90.7%
The estimate for compound 3 lay 25.7 percentage points below the measured number; measured number outside the range, above it.
By their numbers in this assay, from the lowest: compound 2; then compounds 1 and 3 (each within the scatter of the next).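

In this assay, going by these compounds alone, the exchange of (pyridin-2-yl)methyl for pyridin-4-yl on an amine nitrogen in a ring gives a number 8.3 percentage points higher from compound 1 to compound 3 (within the scatter) and is the first single-change step read at this position of the series. The two compounds cannot be told apart on this read-out, so the position accepts this change without a separable effect at the one concentration tested. The entering group has 6 heavy atoms against 7 for the leaving group, both groups hold one six-membered aromatic ring with 1 hetero atom, and this difference in the substituent leaves no mark beyond the scatter. No measurement at hand bears on why the step is this small.

The compounds shown leave open whether a plain phenyl group, without a ring nitrogen, or an acetyl group on the same nitrogen would stay level with compound 1 and compound 3 in this assay. They also leave open whether the two compounds would still match at lower concentrations, since a single-concentration read-out gives no potency.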